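This account rests on a few compounds, and the source may have more. Where it says the series, first, only, none or still open, it means among the compounds named here.

Compound 2 `COc1ccc(/C=C2\CCC/C(=C\c3ccccc3Br)C2=O)cc1OC` gives 8400 nM in a functional assay on HT-1080 cells (Homo sapiens) for cytotoxicity, read by MTT assay, with a stated time of 72 h (a lower number here means a stronger inhibitor, a higher number a weaker inhibitor), while compound 1 `COc1cccc(/C=C2\CCC/C(=C\c3cccc(Br)c3)C2=O)c1OC` gives 12200 nM; these two numbers lie within the usual scatter of each other, so compound 2 stands as one of a pair that the measurements cannot yet separate. Compound 3 `COc1ccc(/C=C2\CCC/C(=C\c3ccc(Cl)c(Cl)c3)C2=O)cc1OC` differs from compound 2 by 3,4-dichlorophenyl in place of 2-bromophenyl on a double-bonded chain carbon bound to a double-bonded ring carbon. Within the data shown here, with no measured step of this kind to lean on, only a small step is expected, a 1.2-fold lower number from compound 2 to compound 3 (0.08 log units; within the scatter), no larger than the scatter. Compound 3 is therefore estimated at 7000 nM, within a range from 3000 nM to 16000 nM.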

Compound 3, half-maximal inhibitory concentration: 3100 nM
Estimate against measurement, compound 3: 2.3-fold (0.35 log units) above, within the range that was stated.
By their numbers in this assay, from the lowest: compound 3; then compounds 2 and 1 (each within the scatter of the next).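

In this assay, among these compounds, putting 3,4-dichlorophenyl in place of 2-bromophenyl gives a 2.7-fold lower number from compound 2 to compound 3 (0.43 log units; beyond the scatter), the only step here that lies beyond the scatter. It shows that the number can respond to the group on this double-bonded chain carbon, although the step is modest and rests on a single pair. Nothing measured here explains the drop. Still open, on these data alone, is which part of the change counts, the swap of bromine for chlorine or their places on the ring, and whether an amine or a carboxylic acid at this position would lower the number further.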